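Trifluoromethyl Step Carried Over to a Second Core

The source may report more compounds than this note shows. Statements on the series, on what has been measured and on what is new or still open speak of the compounds shown alone.

Measured compounds:
compound 1, `Cc1ccc(-c2cn(-c3ccc(CN4CCN(C)CC4)cc3)nn2)cc1Nc1nccc(-c2cccnc2)n1`, 6740 nM
compound 2, `Cc1ccc(-c2cn(-c3ccc(CN4CCN(C)CC4)c(C(F)(F)F)c3)nn2)cc1Nc1nccc(-c2cccnc2)n1`, 20 nM
compound 3, `Cc1ccc(-c2nnc(-c3ccc(CN4CCN(C)CC4)cc3)o2)cc1Nc1nccc(-c2cccnc2)n1`, 570 nM

Of the compounds shown here, three have been tested in a functional assay on HL-60 cells (Homo sapiens) for inhibition, read by MTT assay, with a stated time of 72 h (on this read-out lower numbers stand for stronger inhibition and higher numbers for weaker inhibition), and a fourth, compound 4, `Cc1ccc(-c2nnc(-c3ccc(CN4CCN(C)CC4)c(C(F)(F)F)c3)o2)cc1Nc1nccc(-c2cccnc2)n1`, is still to be measured. Compound 1 gives 6740 nM in this assay. Compound 2 differs from it in one place: trifluoromethyl in place of hydrogen on an aromatic carbon. That change produced a 340-fold lower number from compound 1 to compound 2 (2.53 log units; beyond the scatter).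

Compound 3 carries a different core and gives 570 nM in this assay; the difference between the two cores is not broken down here. Compound 4 is to compound 3 what compound 2 is to compound 1: trifluoromethyl in place of hydrogen on an aromatic carbon. The place described for this change is the same word for word in both pairs, so it is the same kind of change, made on a different core.

Since the change is the same and sits in the same surroundings, the measured step is the guide here: a 340-fold lower number from compound 1 to compound 2 (2.53 log units; beyond the scatter). For compound 4 a step of similar kind is expected, although the core differs and the full size may not carry over, so the estimated step in this assay is a 140-fold lower number from compound 3 to compound 4 (2.15 log units; beyond the scatter). For compound 4 the expected value in this assay is 4 nM, with a range estimated from 1 nM to 20 nM.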

Compound 4, half-maximal inhibitory concentration: 50 nM
Compound 4: middle estimate off by 13-fold (1.10 log units), on the low side, and the stated range ends below it.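

In this assay, the trifluoromethyl change lowers the number on the second core as it did on the first, with an 11-fold lower number from compound 3 to compound 4 (1.06 log units; beyond the scatter), so the direction of the step holds in both pairs. For the compounds shown here, the size of the step does not carry over, and the two steps differ by more than the scatter: the same change on two cores in this assay, a 340-fold lower number (2.53 log units; beyond the scatter) from compound 1 to compound 2 and an 11-fold lower number (1.06 log units; beyond the scatter) from compound 3 to compound 4, 30-fold (1.47 log units) apart, beyond the scatter of two such steps With only one pair on each core, these results give no rule for the size of the step on a further core, and they do not show what makes it smaller on the core of compound 3 than on the core of compound 1.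

The compounds shown leave open whether a chlorine atom, a methyl group or a methoxy group on the same aromatic carbon would also give a step that differs between the two cores. They also leave open how the (4-methylpiperazin-1-yl)methyl group, which is present in all four compounds, bears on the step, and whether the two cores would still differ in this way with a morpholine or a dimethylamine in place of the methylpiperazine.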